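This account rests on a few compounds, and the source may have more. Where it says the series, first, only, none or still open, it means among the compounds named here.

The study records a physicochemical assay for lipophilicity (on this read-out higher numbers stand for higher lipophilicity and lower numbers for lower lipophilicity), for a small set of compounds built on one shared core. Compound 1 `COC(C)CCOCn1cc[n+](C)c1/C=N/O` gives -2.22 in this assay. Compound 2 `C[n+]1ccn(COCCC[Si](C)(C)C)c1/C=N/O` gives 0.43, and compound 3 `C[n+]1ccn(COCCCBr)c1/C=N/O` gives -1.76. Among these three numbers compound 3 stands second highest: its nearest neighbour is compound 1, with a number 0.46 log units higher from compound 1 to compound 3 (beyond the scatter), and its furthest is compound 2, with a number 2.19 log units lower from compound 2 to compound 3 (beyond the scatter).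

Compound 4 `C[n+]1ccn(COCC(C)(C)CBr)c1/C=N/O` differs from compound 3 by a group of 5 heavy atoms (4 carbon, 1 bromine; no ring) in place of a group of 3 heavy atoms (2 carbon, 1 bromine; no ring), on a saturated chain carbon bound to an oxygen on a saturated carbon. Within the data shown here, no measured step matches this change exactly, but two steps bear on it. In the step of a number 2.65 log units higher from compound 1 to compound 2 (beyond the scatter) a chain with more carbon and a silicon atom replaced a chain holding an oxygen. In the step of a number 2.19 log units lower from compound 2 to compound 3 (beyond the scatter) a chain of four heavy atoms shrank to a single bromine. Both steps show that a longer saturated chain goes with a higher number in this assay, and both were large. The present change adds only two carbon atoms to the chain and keeps the bromine, so a smaller rise is expected than in either of those steps.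

The expected step is therefore a number 0.86 log units higher from compound 3 to compound 4 (beyond the scatter), and compound 4 is estimated at -0.9, in a range from -1.5 to -0.3.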

Compound 4, distribution coefficient: -0.81
Estimate against measurement, compound 4: 0.09 log units below; measured number inside the range.
By their numbers in this assay, from the lowest: compound 1; then compound 3; then compound 4; then compound 2.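

With the bromine kept on both sides, the group of 5 heavy atoms (4 carbon, 1 bromine) in place of 2-bromoethyl gives a number 0.95 log units higher from compound 3 to compound 4 (beyond the scatter) in this assay on this saturated chain carbon bound to an oxygen on a saturated carbon, and this is the first step shown in which the chain gains carbon while no other kind of atom in it changes. That gain does not bring the bromine series level with the silicon-bearing chain, since a number 1.24 log units lower from compound 2 to compound 4 (beyond the scatter) remains beyond the scatter, whereas a number 1.41 log units higher from compound 1 to compound 4 (beyond the scatter) shows that the same group of 5 heavy atoms also stands well clear of the oxygen-bearing chain of the same heavy-atom count. Nothing shown gives a reason for the size of any of these steps.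

The compounds shown leave open how much of the rise would remain with a chlorine atom, a hydroxyl group or an amine in place of the bromine. They also do not tell whether a longer chain carrying bromine would continue the rise seen in this assay or level off.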